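Swapping the aryl on the piperazine of compound 3

This account rests on a few compounds, and the source may have more. Where it says the series, first, only, none or still open, it means among the compounds named here.

Of the compounds shown here, three sharing one core have been measured in an assay on a cell-free system (plasma) for inhibition of Dipeptidyl peptidase 4 (Rattus norvegicus), read by fluorescence; on this read-out higher numbers stand for weaker inhibition and lower numbers for stronger inhibition. Compound 1 `O=C([C@@H]1C[C@H](N2CCN(c3ccccn3)CC2)CN1)N1CCSC1` gives 3.5 nM, compound 2 `N#Cc1ccnc(N2CCN([C@@H]3CN[C@H](C(=O)N4CCSC4)C3)CC2)c1` gives 1.9 nM, and compound 3 `O=C([C@@H]1C[C@H](N2CCN(c3ccc(Cl)c(Cl)c3)CC2)CN1)N1CCSC1` gives 4.2 nM. Compound 3 stands highest of the three numbers, though its step of a 1.2-fold higher number from compound 1 to compound 3 (0.08 log units; within the scatter) lies within the scatter, while the step of a 2.2-fold higher number from compound 2 to compound 3 (0.34 log units; beyond the scatter) is modest. The step of a 1.8-fold lower number from compound 1 to compound 2 (0.27 log units; within the scatter) shows a cyano group added on an aromatic carbon without a clear effect.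

Compound 4 `N#Cc1ccc(N2CCN([C@@H]3CN[C@H](C(=O)N4CCSC4)C3)CC2)cc1` differs from compound 3 in one place: 4-cyanophenyl in place of 3,4-dichlorophenyl on an amine nitrogen in a ring. The two steps that change the aryl group on that ring nitrogen, from compound 1 to compound 3 and from compound 2 to compound 3, were small, and so was the addition of the cyano group from compound 1 to compound 2. In this assay compound 4 is therefore expected to sit close to compound 3, perhaps a little lower, a step of a 1.4-fold lower number from compound 3 to compound 4 (0.15 log units; within the scatter). The estimate for compound 4 is 3 nM, within 1.2 nM to 7.5 nM.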

Compound 4, half-maximal inhibitory concentration: 4.7 nM
Compound 4: the middle estimate sits 1.6-fold (0.19 log units) below what was measured, and the stated range covers the measured number.
By their numbers in this assay, from the lowest: compounds 2, 1, 3 and 4 (each within the scatter of the next, the first and the last beyond it).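

Replacing the chlorines with a nitrile on the carbon-only aromatic ring leaves the number in this assay unchanged within the scatter (a 1.1-fold higher number from compound 3 to compound 4 (0.05 log units; within the scatter)), and the same holds against the pyridin-2-yl group (a 1.3-fold higher number from compound 1 to compound 4 (0.13 log units; within the scatter)). With the nitrile kept, replacing 4-cyanopyridin-2-yl with 4-cyanophenyl gives a modest step beyond the scatter (a 2.5-fold higher number from compound 2 to compound 4 (0.39 log units; beyond the scatter)), so the nitrile alone does not carry compound 4 to the number of compound 2; among the compounds shown, both carbon-only aryl groups now stand apart from compound 2, although compound 1, which also carries a pyridine ring, lies within the scatter of compound 3 and compound 4. No measurement at hand accounts for this difference.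

As far as these compounds go, what a carboxylic acid or a primary amine would do in place of the nitrile on this ring remains open. So does the effect of a pyrimidin-2-yl group on the same ring nitrogen.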